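This account rests on a few compounds, and the source may have more. Where it says the series, first, only, none or still open, it means among the compounds named here.

Measured compounds:
compound 1 `COc1ccc(F)cc1CNCCCNc1ccnc2cc(Cc3ccc(F)cc3Cl)ccc12`: 2460 nM
compound 2 `Fc1ccc(Cc2ccc3c(NCCCNCc4ccco4)ccnc3c2)cc1`: 5600 nM

In an ADME assay on HepG2 cells (Homo sapiens) for cytotoxicity, read by luminescence, CellTiter-Glo and ATP content, with a stated time of 72 h (on this read-out higher numbers stand for an effect only at larger amounts of compound and lower numbers for an effect already at smaller amounts), compound 1 gives 2460 nM, the lowest of the two numbers. Compound 2 gives 5600 nM, and that gap lies beyond the scatter, so compound 1 shows its effect at smaller amounts than compound 2.

The step under consideration goes from compound 1 to compound 3 `COc1ccc(F)cc1CNCCCNc1ccnc2cc(Oc3ccccc3OC)ccc12`, which is not yet measured. The change: 2-methoxyphenoxy in place of 2-chloro-4-fluorobenzyl on an aromatic carbon. Among the compounds with values here, no measured pair carries this same change, so the size of the step is open. The whole spread seen so far runs only between compound 1 at 2460 nM and compound 2 at 5600 nM, and a step of similar or smaller size in this assay is expected here, more likely toward a higher number than a lower one, and possibly none beyond the scatter. Compound 3 is accordingly estimated at 4000 nM, range 1500 nM to 11000 nM, meaning an expected step of a 1.6-fold higher number from compound 1 to compound 3 (0.21 log units; within the scatter).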

Compound 3, half-maximal effective concentration: 6400 nM
Compound 3: the middle estimate sits 1.6-fold (0.20 log units) below what was measured; the range from low to high includes it.
By their numbers in this assay, from the lowest: compound 1; then compounds 2 and 3 (each within the scatter of the next).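

In this assay, within the data shown here, 2-methoxyphenoxy in place of 2-chloro-4-fluorobenzyl on the aromatic carbon of the shared core gives a 2.6-fold higher number from compound 1 to compound 3 (0.42 log units; beyond the scatter), the only step that can be read at this position, as compound 1 and compound 2 differ in more than one place. The two groups match in heavy-atom count and in their one six-membered aromatic ring, yet the entering group carries hydrogen-bond acceptors and the leaving group carries none, so the number at this position responds to a change of this kind. Nothing measured in this series accounts for the size of the step.

Still open, on these data alone, is which part of the change carries the step, the ring substituents or the link to the core; plain phenoxy and plain benzyl at this position would separate the two. Also open, as far as these compounds go, is how this position responds to a group of another kind, such as a carboxylic acid or a morpholine.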